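The source may hold more compounds than are shown below. What is called first, only, known or untested is meant among the compounds shown, and "the series" means these compounds.

Working notes on the benzhydroxamate sulfonamide series. Among the measured compounds shown here, compound 1 `O=C(NO)c1ccc(CN(Cc2ccccc2)S(=O)(=O)c2c(F)c(F)c(F)c(F)c2F)cc1` gives 9 nM in an assay on isolated protein for inhibition of protein deacetylase HDAC6 (Homo sapiens), read by mobility shift assay (on this read-out higher numbers stand for weaker inhibition and lower numbers for stronger inhibition), and stands at the lowest of the three numbers measured so far. Compound 2 `O=C(NO)c1ccc(CN(Cc2ccc(F)cc2)S(=O)(=O)c2c(F)c(F)c(F)c(F)c2F)cc1` gives 13 nM in this assay, and compound 3 `O=C(NO)c1ccc(CN(Cc2ccc(C(F)(F)F)cc2)S(=O)(=O)c2c(F)c(F)c(F)c(F)c2F)cc1` gives 45 nM. The measured steps among them are a 1.4-fold higher number from compound 1 to compound 2 (0.16 log units; within the scatter), a 5.0-fold higher number from compound 1 to compound 3 (0.70 log units; beyond the scatter) and a 3.5-fold higher number from compound 2 to compound 3 (0.54 log units; beyond the scatter).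

Compound 4 `Cc1ccc(CN(Cc2ccc(C(=O)NO)cc2)S(=O)(=O)c2c(F)c(F)c(F)c(F)c2F)cc1` is not yet measured. It differs from compound 1 by methyl in place of hydrogen on an aromatic carbon. The two measured steps at this same position bear on the question: fluoro in place of hydrogen stayed within the scatter, while trifluoromethyl in place of hydrogen gave a modest rise in the number. Methyl enters one heavy atom, which puts the change nearer the first of these than the second, so a small step toward a higher number is expected for compound 4, a 1.8-fold higher number from compound 1 to compound 4 (0.25 log units; within the scatter), with the lower end overlapping the scatter around compound 1. The estimate for compound 4 is 16 nM, within the range 7 nM to 40 nM.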

Compound 4, half-maximal inhibitory concentration: 6 nM
For compound 4 the middle estimate is 2.7-fold (0.43 log units) above the measured one; measured number outside the range, below it.
By their numbers in this assay, from the lowest: compounds 4, 1 and 2 (each within the scatter of the next, the first and the last beyond it); then compound 3.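

Methyl on this aromatic carbon, para to a large group, stays within the scatter of hydrogen in this assay, with a 1.5-fold lower number from compound 1 to compound 4 (0.18 log units; within the scatter), so the rise seen with trifluoromethyl does not extend to every group placed here. The new compound also separates two groups that hydrogen could not: a 2.2-fold lower number from compound 2 to compound 4 (0.34 log units; beyond the scatter) and a 7.5-fold lower number from compound 3 to compound 4 (0.88 log units; beyond the scatter), both beyond the scatter, although fluoro and methyl each stay within the scatter of hydrogen. No available evidence accounts for this ordering of the groups.

The compounds shown cover only hydrogen, fluoro, methyl and trifluoromethyl at this one carbon on the shared core. Going by these compounds, whether methoxy, an amine, a carboxylic acid or a longer chain such as ethyl would read with methyl or with trifluoromethyl remains open.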